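Removing a propanoyl group from compound 3

The source may hold more compounds than are shown below. What is called first, only, known or untested is meant among the compounds shown, and "the series" means these compounds.

- Compound 1 `CCCCCCCC(=O)Oc1cc(C(=O)C2=C3OC(C)(C)[C@@H](CC=C(C)C)C[C@@]34C[C@@H](CC=C(C)C)C(C)(C)[C@H]3CCC(C)(C)O[C@]34OC2=O)ccc1O`: 15300 nM
- Compound 2 `CC(C)=CC[C@H]1C[C@]23C[C@@H](CC=C(C)C)C(C)(C)[C@H]4CCC(C)(C)O[C@]42OC(=O)C(C(=O)c2ccc(O)c(O)c2)=C3OC1(C)C`: 7690 nM
- Compound 3 `CCC(=O)Oc1ccc(C(=O)C2=C3OC(C)(C)[C@@H](CC=C(C)C)C[C@@]34C[C@@H](CC=C(C)C)C(C)(C)[C@H]3CCC(C)(C)O[C@]34OC2=O)cc1OC(=O)CC`: > 20000 nM (a limit, not a number)

All these results come from a functional assay on K562 cells (Homo sapiens) for antiproliferative activity, read by MTT assay, with a stated time of 72 h; on this read-out higher numbers stand for weaker inhibition and lower numbers for stronger inhibition. Compound 3 stands at > 20000 nM, which is a limit and not a number. The change leading to compound 4 `CCC(=O)Oc1cc(C(=O)C2=C3OC(C)(C)[C@@H](CC=C(C)C)C[C@@]34C[C@@H](CC=C(C)C)C(C)(C)[C@H]3CCC(C)(C)O[C@]34OC2=O)ccc1O` is hydrogen in place of propanoyl on an oxygen on an aromatic ring, so propanoyloxy becomes hydroxy.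

One measured step is of the same kind, hydrogen in place of heptylcarbonyl on an oxygen on an aromatic ring. It is a 2.0-fold lower number from compound 1 to compound 2 (0.30 log units; within the scatter), and on its own it promises no real shift. Compound 3 gives no exact starting number, so the size of the new step stays uncertain. Compound 4 is expected to land in the same region as compound 1 at 15300 nM and compound 2 at 7690 nM. In this assay the estimated change is an at least 1.8-fold lower number from compound 3 to compound 4 (0.25 log units; that floor lies within the scatter), modest and towards stronger inhibition. For compound 4 the estimate is 11000 nM, with an expected range from 5500 nM to 20000 nM.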

Compound 4, half-maximal inhibitory concentration: 12100 nM
For compound 4 the middle estimate is 1.1-fold (0.04 log units) below the measured one; measured number inside the range.
By their numbers in this assay, from the lowest: compounds 2, 4 and 1 (each within the scatter of the next). At a limit, above all of these: compound 3.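

Compound 3 stands at a limit and not at a number in this assay: the limit of > 20000 nM in this assay, at which 1 of the 4 values shown sits. Replacing one of its propanoyloxy groups with hydroxy gives an at least 1.6-fold lower number from compound 3 to compound 4 (0.21 log units; that floor lies within the scatter) and so fixes only a floor for this change. Once a single ester remains, the other steps are small: adding propanoyl to the free hydroxy gives a 1.6-fold higher number from compound 2 to compound 4 (0.20 log units; within the scatter) and cutting the heptylcarbonyl chain down to propanoyl gives a 1.3-fold lower number from compound 1 to compound 4 (0.10 log units; within the scatter), so neither the presence of this one ester nor the length of its chain separates these compounds.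

As far as these compounds go, the true cost of the second propanoyl group stays open as long as compound 3 has only a limit. Also open, from the compounds shown here alone, is how this assay would respond to a methyl ether, or to an ester chain ending in an amine or a carboxylic acid, on this oxygen.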